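Thioether variation on the benzothiazole amide series

The compounds below may be only part of what the source reports. "The series", "measured", "known", "first", "only" and "open" are said of these compounds alone.

Measured compounds:
Compound 1 `O=C(CSc1cccc(O)c1)Nc1ccc2nc(NC(=O)c3ccc(C(F)(F)F)cc3)sc2c1` — 510 nM
Compound 2 `CCCC(=O)Nc1nc2ccc(NC(=O)CSc3cccc(O)c3)cc2s1` — 10600 nM
Compound 3 `Cc1cc(C)cc(C(=O)Nc2nc3ccc(NC(=O)CSc4cccc(O)c4)cc3s2)c1` — 5130 nM

All three were run in a functional assay on HCT-116 cells (Homo sapiens) for antiproliferative activity, read by MTT assay, with a stated time of 72 h; on this read-out lower numbers stand for stronger inhibition and higher numbers for weaker inhibition. Compound 1 gives the lowest number of the three, with compound 3 nearest, as a 10-fold higher number from compound 1 to compound 3 (1.00 log units; beyond the scatter) shows, and compound 2 furthest, as a 21-fold higher number from compound 1 to compound 2 (1.32 log units; beyond the scatter) shows. Both of those steps change the group on the carbonyl carbon of the amide attached to the shared core; the step of a 2.1-fold lower number from compound 2 to compound 3 (0.32 log units; beyond the scatter) likewise sits on that carbonyl carbon.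

Compound 4 `O=C(CSC1CCCCC1)Nc1ccc2nc(NC(=O)c3ccc(C(F)(F)F)cc3)sc2c1` has not yet been measured. It differs from compound 1 at the other end of the molecule: cyclohexyl in place of 3-hydroxyphenyl on a sulfur. Within the data shown here, none of the measured steps touches the sulfur, so no step in this set bears directly on this change, and the size and direction of its effect in this assay cannot be read from the numbers in hand. The carbonyl end of compound 4 is the one that gave the lowest number here in compound 1, so compound 4 is expected to stay in the region of compound 1, with a wide margin either way. The estimate for compound 4 is 900 nM, with a range from 250 nM to 3500 nM, which corresponds to an expected step of a 1.8-fold higher number from compound 1 to compound 4 (0.25 log units; within the scatter).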

Compound 4, half-maximal inhibitory concentration: 21000 nM
The estimate for compound 4 lay 23-fold (1.37 log units) below the measured number, and the stated range ends below it.
By their numbers in this assay, from the lowest: compound 1; then compound 3; then compounds 2 and 4 (each within the scatter of the next).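

The sulfur end of the molecule matters as much as the carbonyl end: in this assay, with the 4-(trifluoromethyl)phenyl group held constant, cyclohexyl in place of 3-hydroxyphenyl on a sulfur gives a 41-fold higher number from compound 1 to compound 4 (1.61 log units; beyond the scatter). This step is large, as is the change on the carbonyl carbon in a 21-fold higher number from compound 1 to compound 2 (1.32 log units; beyond the scatter), so the low number of compound 1 depends on both ends of the molecule. The change removes the aromatic ring and the hydroxyl together, and nothing at hand accounts for the step.

On these data alone, whether the hydroxyl or the aromatic ring carries the difference stays open; an unsubstituted phenyl or a 3-methoxyphenyl on the sulfur would separate the two. Also open, as far as these compounds go, is whether the same change has a similar effect with the propyl group of compound 2 or the 3,5-dimethylphenyl group of compound 3 on the carbonyl carbon.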